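Methylpiperazinyl for Hydroxy: Weighing a Step on Compound 1

The source may hold more compounds than are shown below. What is called first, only, known or untested is meant among the compounds shown, and "the series" means these compounds.

Among the compounds with values here, compound 1 `N#Cc1c(O)nc(SCc2nc3ccccc3[nH]2)nc1-c1ccccc1` stands lowest of the two numbers so far in a functional assay on SK-OV-3 cells (Homo sapiens) for cytotoxicity, read by MTT assay, with a stated time of 3 days (on this read-out higher numbers stand for weaker inhibition and lower numbers for stronger inhibition), where compound 1 gives 2.55 nM. Compound 2 `N#Cc1c(Nc2ccccc2)nc(SCc2nc3ccccc3[nH]2)nc1-c1ccccc1` gives 4.46 nM, and the step of a 1.7-fold higher number from compound 1 to compound 2 (0.24 log units; within the scatter) shows that swapping the hydroxy for an anilino barely moved the read-out. Compound 3 `CN1CCN(c2nc(SCc3nc4ccccc4[nH]3)nc(-c3ccccc3)c2C#N)CC1` differs from compound 1 by 4-methylpiperazin-1-yl in place of hydroxy on an aromatic carbon. Within the data shown here, only that one step bears on this change, and it was within the scatter, so for compound 3 the expected step of a 2.0-fold higher number from compound 1 to compound 3 (0.29 log units; within the scatter) is small or none beyond the scatter. Compound 3 is estimated at 5 nM, within 1.5 nM to 16 nM.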

Compound 3, half-maximal inhibitory concentration: 1600 nM
The estimate for compound 3 lay 320-fold (2.51 log units) below the measured number; measured number outside the range, above it.
By their numbers in this assay, from the lowest: compounds 1 and 2 (each within the scatter of the next); then compound 3.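

In this assay this position proved far from indifferent: the step of a 630-fold higher number from compound 1 to compound 3 (2.80 log units; beyond the scatter) and the step of a 360-fold higher number from compound 2 to compound 3 (2.55 log units; beyond the scatter) are both large, although hydroxy and anilino had stayed within the scatter of each other. The tolerance seen with those two groups therefore did not extend to 4-methylpiperazin-1-yl. No measurement shown here accounts for this drop. Going by these compounds, whether a morpholine, a piperidine or an open-chain dimethylamino group on the same carbon would stand with compound 2 or with compound 3 remains open.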